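Methoxy removal on the pendant phenyl in the indole series

A few compounds are considered here, and "the series" means these few. Any claim that something is new, unique, unknown or untested is made for them only; others in the source may bear on it.

Three compounds have numbers in a functional assay on DU-145 cells (Homo sapiens) for inhibition, read by sulforhodamine B assay, with a stated time of 48 h; a higher number here means a weaker inhibitor of growth, a lower number a stronger inhibitor of growth. Compound 3 `COc1ccc(-c2[nH]c3ccc(OC)cc3c2C=C(C#N)C#N)cc1` gives 917 nM; compound 1 `COc1ccc2[nH]c(-c3ccccc3)c(C=C(C#N)C#N)c2c1` gives 6500 nM; compound 2 `COc1ccc(-c2[nH]c3ccc(OC)cc3c2/C=C(\C#N)S(=O)(=O)c2ccccc2)cc1` gives 875 nM. From compound 3 to compound 1 the change is hydrogen in place of methoxy on an aromatic carbon, and it produced a 7.1-fold higher number from compound 3 to compound 1 (0.85 log units; beyond the scatter). Compound 2 and compound 3 share the same substituted indole, but the difference between the two cores is not broken down here; their values in this assay sit within the scatter of each other.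

Compound 4 `COc1ccc2[nH]c(-c3ccccc3)c(/C=C(\C#N)S(=O)(=O)c3ccccc3)c2c1` is not yet measured. From compound 2 to compound 4 the change is hydrogen in place of methoxy on an aromatic carbon, the same change as from compound 3 to compound 1, at the same kind of place.

The expected step is a 6.9-fold higher number from compound 2 to compound 4 (0.84 log units; beyond the scatter), because a 7.1-fold higher number from compound 3 to compound 1 (0.85 log units; beyond the scatter) was seen for the identical change. Compound 4 is therefore estimated at 6000 nM, with a likely range of 2500 nM to 15000 nM.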

Compound 4, concentration for 50% growth inhibition: 10100 nM
Beside the measured number, compound 4's estimate is 1.7-fold (0.23 log units) below it; the range from low to high includes it.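

In this assay, hydrogen in place of methoxy (4-methoxyphenyl to phenyl) gave a 12-fold higher number from compound 2 to compound 4 (1.06 log units; beyond the scatter), so compound 4 is clearly weaker than compound 2. The change carries across both cores in the same direction, and the two step sizes cannot be told apart: the same change on two cores in this assay, a 7.1-fold higher number (0.85 log units; beyond the scatter) from compound 3 to compound 1 and a 12-fold higher number (1.06 log units; beyond the scatter) from compound 2 to compound 4, 1.6-fold (0.21 log units) apart, within the scatter of two such steps. This rests on two pairs in one cell line, so it does not show that the step would hold on other cores or in other assays, nor does it explain why methoxy matters.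

Still open, as far as these compounds go, is how other groups on that aromatic carbon would compare, such as a hydroxyl, an amine or an ethoxy. Also open, from the compounds shown here alone, is what the methoxy kept on the core by all four compounds contributes.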